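Three Amides at the Limit and a Fourth Expected There

The source may hold more compounds than are shown below. What is called first, only, known or untested is meant among the compounds shown, and "the series" means these compounds.

Compound 1 `O=C(Nc1ccc(Cl)cc1)c1cc(=O)[nH]c2cc(Br)ccc12` gives > 20000 nM in a functional assay on KYSE-70 cells for antiproliferative activity against KYSE-70 cell line (Homo sapiens), read by MTT assay, with a stated time of 72 h; on this read-out lower numbers stand for stronger inhibition and higher numbers for weaker inhibition.
Compound 2 `O=C(Nc1ccc(C(F)(F)F)cc1)c1cc(=O)[nH]c2cc(Br)ccc12` gives > 20000 nM in this assay.
Compound 3 `O=C(Nc1cccc(C(F)(F)F)c1)c1cc(=O)[nH]c2cc(Br)ccc12` gives > 20000 nM in this assay.

All three measured compounds share one core and differ only in the group on the aromatic ring of the anilide. For compound 1 the value is a limit of the assay, not a number. For compound 2 the value is likewise a limit. For compound 3 the value is also a limit. Between compound 2 and compound 1 the change is chloro in place of trifluoromethyl on an aromatic carbon, and the step that the two limits leave unreadable from compound 2 to compound 1 cannot be read, because of the limit of > 20000 nM in this assay, at which 3 of the 3 values shown sit. The difference between the cores of compound 2 and compound 3 is not broken down here.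

Compound 4 `O=C(Nc1cccc(Cl)c1)c1cc(=O)[nH]c2cc(Br)ccc12` has not yet been measured in this assay. It differs from compound 3 by chloro in place of trifluoromethyl on an aromatic carbon. Going by the values given here, this is the same kind of change as the one from compound 2 to compound 1, but the place differs: there the chloro sits para to a large group, here meta to a large group. Among the compounds with values here, since the only earlier example of this change gave an unreadable step and every measured value sits at the limit, compound 4 is expected to sit at the limit as well, a step that the limit leaves unreadable from compound 3 to compound 4 being estimated. The estimate for compound 4 is 30000 nM, expected between 10000 nM and 100000 nM.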

Compound 4, half-maximal inhibitory concentration: > 20000 nM
Compound 4 ended at the assay's limit; the forecaster's own chance of this, stated with the estimate: 85%; the middle value does not contradict the limit.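

Neither the step from compound 3 to compound 4 nor the step from compound 1 to compound 4 can be read, because each of these compounds gives a limit and not a number: the limit of > 20000 nM in this assay, at which 4 of the 4 values shown sit.

The compounds shown leave open whether any group on the aromatic ring of the anilide would give a number rather than a limit in this assay, and how far these four compounds differ from one another.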